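This account rests on a few compounds, and the source may have more. Where it says the series, first, only, none or still open, it means among the compounds named here.

Measured set:
- compound 1 `O=C(N/N=C/c1ccc(F)cc1)Nc1cc2c(Nc3ccc(F)c(Cl)c3)ncnc2cc1O[C@H]1CCOC1`: in a functional assay on PC-3 cells (Homo sapiens) for cytotoxicity, read by MTT assay, with a stated time of 72 h (a higher number here means a weaker inhibitor, a lower number a stronger inhibitor), compound 1 is reported as "not active" (no number reported)
- compound 2 `O=C(N/N=C/c1ccc([N+](=O)[O-])cc1)Nc1cc2c(Nc3ccc(F)c(Cl)c3)ncnc2cc1O[C@H]1CCOC1`: compound 2 gives 33500 nM
- compound 3 `COc1cc2ncnc(Nc3ccc(F)c(Cl)c3)c2cc1NC(=O)N/N=C/c1ccc([N+](=O)[O-])cc1`: compound 3 gives 32400 nM

Compound 3 holds the lower of the two numbers in hand, with compound 2 nearest; the step of a 1.0-fold lower number from compound 2 to compound 3 (0.01 log units; within the scatter) is within the scatter, so the two cannot be ordered. Compound 1 carries no number at all.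

Compound 4 `COc1cc2ncnc(Nc3ccc(F)c(Cl)c3)c2cc1NC(=O)N/N=C/c1ccc(O)cc1` is not yet measured and differs from compound 3 by hydroxy in place of nitro on an aromatic carbon. Within the data shown here, no measured step bears directly on this change: the only step in hand, a 1.0-fold lower number from compound 2 to compound 3 (0.01 log units; within the scatter), alters the group on the oxygen of the shared core and is within the scatter. Compound 1 is reported as "not active" (no number reported) and compound 2 as 33500 nM, so the set spans weak to unmeasurable, and a change on this ring can leave no number. Compound 4 is expected to stay near compound 3, with the expected step of a 1.2-fold higher number from compound 3 to compound 4 (0.09 log units; within the scatter) inside the scatter and a fair chance of no number. Compound 4 is estimated at 40000 nM, range 12000 nM to 150000 nM.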

Compound 4, half-maximal inhibitory concentration: 16600 nM
Compound 4: middle estimate off by 2.4-fold (0.38 log units), on the high side; measured number inside the range.
By their numbers in this assay, from the lowest: compounds 4, 3 and 2 (each within the scatter of the next).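

In this assay, the change from 4-nitrophenyl to 4-hydroxyphenyl gives a 2.0-fold lower number from compound 3 to compound 4 (0.29 log units; within the scatter). Among these compounds, this is the first readable step on this ring, as the earlier step concerned only the group on the oxygen of the shared core, and it shows that replacing nitro with the smaller hydroxy, which adds a hydrogen-bond donor, does not move the number beyond the scatter at this position, para to a large group. No measured data on the compounds offer an explanation for this step.

On these data alone, whether an amine or a carboxylic acid at this position would give a step beyond the scatter remains open. Also open, as far as these compounds go, is whether hydroxy in place of nitro would read the same with oxolan-3-yl rather than methyl on the oxygen of the shared core.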